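A few compounds are considered here, and "the series" means these few. Any claim that something is new, unique, unknown or untested is made for them only; others in the source may bear on it.

The measured compounds and their values:

Compound 1, `CCOc1ccc(F)cc1C(C)NC(=O)N(C)S(=O)(=O)c1ccc(Cl)cc1`, gives 24500 nM.
Compound 2, `CCOc1ccc(Br)cc1C(C)NC(=O)N(C)S(=O)(=O)c1ccc(Cl)cc1`, gives 55700 nM.
Compound 3, `COc1ccc(Br)cc1C(C)NC(=O)NS(=O)(=O)c1ccc(Cl)cc1`, gives 80900 nM.

All three were tested in a functional assay on thoracic aorta (Rattus norvegicus, strain Wistar), with a stated time of 15 min; a higher number here means that more compound is needed for the effect, a lower number that less compound is needed. Compound 3 has the highest number of the three; its nearest neighbour is compound 2, and the two values of compound 2 and compound 3 lie within the usual scatter of each other, so no order between them can be claimed. Compound 1 stands furthest from compound 3. Compound 2 and compound 1 differ in one place: fluoro in place of bromo on an aromatic carbon. That step is a 2.3-fold lower number from compound 2 to compound 1 (0.36 log units; beyond the scatter).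

Compound 4, `COc1ccc(F)cc1C(C)NC(=O)NS(=O)(=O)c1ccc(Cl)cc1`, has not yet been measured in this assay. It differs from compound 3 in the same kind of change: fluoro in place of bromo on an aromatic carbon. The surroundings are not the same word for word: in compound 2 the place is para to an ethoxy group (3 heavy atoms), in compound 3 it is para to a methoxy group (2 heavy atoms). How the core of compound 3 differs from the core of compound 2 is not broken down here.

Resting on the step from compound 2 to compound 1, a 2.3-fold lower number from compound 2 to compound 1 (0.36 log units; beyond the scatter), a similar modest step is expected for compound 4, so that the change from compound 3 to compound 4 is estimated as a 2.2-fold lower number from compound 3 to compound 4 (0.35 log units; beyond the scatter). For compound 4 the expected value in this assay is therefore 36000 nM, with a likely range from 14000 nM to 90000 nM.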

Compound 4, half-maximal effective concentration: > 300000 nM
Compound 4 ended at the assay's limit; the forecaster's own chance of this, stated with the estimate: 10%; at least 8.3-fold (0.92 log units) between middle value and limit.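

In this assay compound 4 gives > 300000 nM, which is a limit of the assay and not a number. Even so, the step can be read in one direction: fluoro in place of bromo, on the aromatic carbon para to a methoxy group, gives an at least 3.7-fold higher number from compound 3 to compound 4 (0.56 log units; beyond the scatter), and the same change therefore did not carry over from the core of compound 2 to the core of compound 3, where its direction is reversed: the same change on two cores in this assay, a 2.3-fold lower number (0.36 log units; beyond the scatter) from compound 2 to compound 1 and an at least 3.7-fold higher number (0.56 log units; beyond the scatter) from compound 3 to compound 4, at least 8.4-fold (0.92 log units) apart, beyond the scatter of two such steps

Among the compounds shown here, this rests on only two pairs, however, and it does not show which difference between the two cores goes with the reversal, nor how large the step from compound 3 to compound 4 really is, since only its lower bound can be read.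

The compounds shown leave open whether the swap from the ethoxy group to the methoxy group alone would reverse the step, or whether another part of the core is involved. They also leave open how the same position would behave with a propoxy chain in place of the methoxy group, or with an amine or a nitrile in place of the halogen.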